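A few compounds are considered here, and "the series" means these few. Any claim that something is new, unique, unknown or untested is made for them only; others in the source may bear on it.

In a functional assay on SGC-7901 cells (Homo sapiens) for cytotoxicity, read by MTT assay, with a stated time of 48 h (on this read-out lower numbers stand for stronger inhibition and higher numbers for weaker inhibition), three compounds on a shared core have been read so far. Compound 1 (`CCCc1nn(C)c(C(N)=O)c1NC(=O)/C=C/c1ccccc1`) gives 8110 nM and compound 2 (`CCCc1nn(C)c(C(N)=O)c1NC(=O)c1cc(OC)c(OC)c(OC)c1`) gives 13400 nM while compound 3 (`CCCc1nn(C)c(C(N)=O)c1NC(=O)c1cc(OC)c(OC)cc1OC`) gives 34800 nM on the same scale. Compound 1 and compound 2 lie within the usual scatter of each other and together form the low end of this small set. Compound 3 stands apart from compound 1 by a margin beyond the scatter, on the side of weaker inhibition.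

The unmeasured compound 4 (`CCCc1nn(C)c(C(N)=O)c1NC(=O)/C=C/c1ccco1`) keeps the core and the double-bonded chain of compound 1 and carries furan-2-yl in place of phenyl on a double-bonded chain carbon bound to a double-bonded chain carbon. Within the data shown here, no two measured compounds differ in one place only, so the series offers no direct precedent for this exchange. The expectation therefore rests on compound 1 at 8110 nM as the starting point, and no step beyond the scatter is expected in this assay. The estimated change is a 1.1-fold higher number from compound 1 to compound 4 (0.05 log units; within the scatter) (expected to stay within the scatter). Compound 4 is estimated at 9000 nM (expected range 4000 nM to 20000 nM).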

Compound 4, half-maximal inhibitory concentration: 8300 nM
Estimate against measurement, compound 4: 1.1-fold (0.04 log units) above; the range from low to high includes it.
By their numbers in this assay, from the lowest: compounds 1, 4 and 2 (each within the scatter of the next); then compound 3.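

In this assay, furan-2-yl in place of phenyl on a double-bonded chain carbon bound to a double-bonded chain carbon gives a 1.0-fold higher number from compound 1 to compound 4 (0.01 log units; within the scatter), the only step shown so far between compounds that differ in one place. At this place, a six-membered aromatic ring of carbon only and a five-membered aromatic ring with 1 hetero atom therefore read alike, so neither the ring size nor the ring oxygen separates compound 1 from compound 4 on this read-out. Nothing measured here accounts for this likeness.

As far as these compounds go, one exchange cannot define the range of groups accepted at this place, so it remains open whether a cyclohexyl ring, a pyridine ring or a phenyl ring carrying a dimethylamino group would also stay within the scatter of compound 1. The shared core also stays the same in every compound shown, which leaves open how a longer chain or a carboxylic acid on it would read, and whether furan-2-yl would behave the same way alongside such a group.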